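Chloro on the benzyl group: what to expect of compound 4

The source may hold more compounds than are shown below. What is called first, only, known or untested is meant among the compounds shown, and "the series" means these compounds.

Measured compounds:
Compound 1 `Cc1nnc(SCc2ccccc2)n1N1C(=O)c2ccccc2C1=O`; in a functional assay on PC-3M cells (Homo sapiens) for cytotoxicity, read by MTT assay, with a stated time of 48 h (on this read-out higher numbers stand for weaker inhibition and lower numbers for stronger inhibition), compound 1 gives > 200000 nM, which is a limit of the assay and not a number.
Compound 2 `Cc1nnc(SCC(=O)c2ccc(Cl)cc2)n1N1C(=O)c2ccccc2C1=O`; in this assay compound 2 gives > 200000 nM, again a limit only.
Compound 3 `Cc1ccc(C(=O)CSc2nnc(C)n2N2C(=O)c3ccccc3C2=O)cc1`; in this assay compound 3 gives > 200000 nM, again a limit only.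

Compound 1 therefore has no number of its own in this assay; it sits at the limit, as do both other measured compounds (the limit of > 200000 nM in this assay, at which 3 of the 3 values shown sit). Every step among the measured compounds is accordingly unreadable: a step that the two limits leave unreadable from compound 1 to compound 2, a step that the two limits leave unreadable from compound 1 to compound 3 and a step that the two limits leave unreadable from compound 2 to compound 3. None can be given a size or a direction.

Compound 4 `Cc1nnc(SCc2ccccc2Cl)n1N1C(=O)c2ccccc2C1=O` differs from compound 1 by chloro in place of hydrogen on an aromatic carbon, benzyl becoming 2-chlorobenzyl. Among the compounds with values here, no measured step touches this change directly; the one pair involving a chloro, from compound 2 to compound 3, is itself unreadable. What remains is that all three measured compounds, with or without chloro, sit at the limit.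

The expected step is therefore a step that the limit leaves unreadable from compound 1 to compound 4, that is, none readable. Compound 4 is estimated to return about 250000 nM in this assay, within 60000 nM to 1000000 nM, most likely as a limit again.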

Compound 4, half-maximal inhibitory concentration: > 200000 nM
Compound 4: a limit, no number; the forecaster's own chance of this, stated with the estimate: 80%; the middle value is on the limit's open side.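

In this assay compound 4 gives > 200000 nM, a limit and not a number. Its steps to compound 1, compound 2 and compound 3 therefore cannot be read: the limit of > 200000 nM in this assay, at which 4 of the 4 values shown sit.

The compounds shown leave open whether chloro in place of hydrogen has any effect on cytotoxicity, and of what size or direction, with no compound here having a number of its own.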